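Vinylsulfonyl piperazine thienopyrimidines: aryl variation at the ring sulfur

This account rests on a few compounds, and the source may have more. Where it says the series, first, only, none or still open, it means among the compounds named here.

Measured compounds and their values:
- compound 1 `C=CS(=O)(=O)N1CCN(c2ncnc3sc(-c4ccccc4)cc23)CC1`: 21100 nM
- compound 2 `C=CS(=O)(=O)N1CCN(c2ncnc3sc(-c4ccc(C(F)(F)F)cc4)cc23)CC1`: 7080 nM
- compound 3 `C=CS(=O)(=O)N1CCN(c2ncnc3sc(-c4cc(Br)cnc4F)cc23)CC1`: 28400 nM

All three share the core of compound 1 and differ only in the aryl group on the aromatic carbon next to the ring sulfur. In a functional assay on MDA-MB-436 cells (Homo sapiens) for antiproliferative activity, read by MTT assay, with a stated time of 48 h (a lower number here means a stronger inhibitor, a higher number a weaker inhibitor), compound 1 gives 21100 nM, the second highest of the three numbers; compound 3 sits nearest to it, and compound 2 furthest. Within the data shown here, the one step that clearly moves the number is a 3.0-fold lower number from compound 1 to compound 2 (0.47 log units; beyond the scatter), where trifluoromethyl replaces hydrogen on the phenyl. The exchange of phenyl for a pyridyl bearing bromine and fluorine, a 1.3-fold higher number from compound 1 to compound 3 (0.13 log units; within the scatter), stays within the scatter, and a 4.0-fold higher number from compound 2 to compound 3 (0.60 log units; beyond the scatter) is modest.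

Compound 4 `C=CS(=O)(=O)N1CCN(c2ncnc3sc(-c4cn(C)nc4C(F)(F)F)cc23)CC1` has not yet been measured. It differs from compound 1 in that (1-methyl-3-(trifluoromethyl)-1H-pyrazol-4-yl in place of phenyl on an aromatic carbon). Among the measured compounds shown here, no measured step covers this exact change; the nearest are the gain of trifluoromethyl in compound 2 and the switch to a hetero-aromatic ring in compound 3. Taken together, a step of no more than modest size is expected, most likely toward a lower number, a 1.5-fold lower number from compound 1 to compound 4 (0.18 log units; within the scatter). For compound 4 the estimate in this assay is 14000 nM, expected to fall between 5000 nM and 40000 nM.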

Compound 4, half-maximal inhibitory concentration: 15100 nM
Compound 4: middle estimate off by 1.1-fold (0.03 log units), on the low side; the range from low to high includes it.
By their numbers in this assay, from the lowest: compound 2; then compounds 4, 1 and 3 (each within the scatter of the next).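

In this assay a five-membered hetero-aromatic ring carrying trifluoromethyl can occupy the aromatic carbon next to the ring sulfur without a clear shift from the six-membered aryl groups: a 1.4-fold lower number from compound 1 to compound 4 (0.15 log units; within the scatter) and a 1.9-fold lower number from compound 3 to compound 4 (0.27 log units; within the scatter) both stay within the scatter, so compound 4 cannot be separated from either compound. Only compound 2 stands apart, with a 2.1-fold higher number from compound 2 to compound 4 (0.33 log units; beyond the scatter), which shows that trifluoromethyl does not by itself bring the lower number of compound 2, since compound 4 also carries that group, on 1-methyl-3-(trifluoromethyl)-1H-pyrazol-4-yl, and still does not match it. No supporting measurement bears on the gap between these two trifluoromethyl-bearing groups.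

The four compounds shown carry only aromatic rings at this position, so it remains open whether a basic amine such as a piperidine, or a carboxylic acid on the phenyl, would take the number below that of compound 2. The vinylsulfonyl group is also constant throughout, which leaves open how an acrylamide in its place would read in this assay.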